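This account rests on a few compounds, and the source may have more. Where it says the series, first, only, none or still open, it means among the compounds named here.

In a functional assay on B16-F10 cells (Mus musculus) for cytotoxicity (a higher number here means a weaker inhibitor, a lower number a stronger inhibitor), compound 1 `O=c1oc2ccccc2c2nc3c(ccc4cc[nH]c43)c(-c3ccc(C(F)(F)F)cc3)c12` gives 70700 nM and compound 2 `O=c1oc2ccccc2c2nc3c(ccc4cc[nH]c43)c(-c3cccc4ccccc34)c12` gives 70700 nM as well, so compound 2 stands level with compound 1. Compound 3 `O=c1oc2ccccc2c2nc3c(ccc4cc[nH]c43)c(-c3ccc(Br)cc3)c12` keeps the shared core and differs from compound 2 in one group, with 4-bromophenyl in place of naphthalen-1-yl on an aromatic carbon as the counted change: 4-bromophenyl in place of naphthalen-1-yl on an aromatic carbon, opposite the ring nitrogen. Among the compounds with values here, one measured step bears on this swap: no change at the digits printed from compound 1 to compound 2 (within the scatter) when naphthalen-1-yl replaced 4-(trifluoromethyl)phenyl at the same carbon. Like 4-(trifluoromethyl)phenyl, the entering 4-bromophenyl has one six-membered aromatic ring of carbon only. A single step is thin evidence, but no change beyond the scatter is expected in this assay and no direction can be called. The estimated move is a 1.0-fold lower number from compound 2 to compound 3 (0.00 log units; within the scatter) and rests on that one comparison. Compound 3 is expected at 70000 nM within an estimated range of 35000 nM to 140000 nM in this measurement.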

Compound 3, half-maximal inhibitory concentration: 70700 nM
The estimate for compound 3 lay 1.0-fold (0.00 log units) below the measured number; the measured number falls inside the stated range.
By their numbers in this assay, from the lowest: compounds 1, 2 and 3 (each within the scatter of the next).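

In this assay, the step to the smaller group with one aromatic ring instead of two shows no change at the digits printed from compound 2 to compound 3 (within the scatter), so at this carbon, opposite the ring nitrogen, the read-out stays level across that difference in ring count. The group at the far end of the phenyl ring can also differ: bromo in place of trifluoromethyl gives no change at the digits printed from compound 1 to compound 3 (within the scatter). No measurement shown here explains why these three compounds read alike.

On these data alone, all three compounds carry an aromatic carbon ring at this position, so it remains open whether a phenyl ring bearing an amine or a carboxylic acid, or a simple alkyl chain in place of the ring, would read differently. The compounds shown also leave open whether a change elsewhere on the shared core would shift the number.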